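Chloro to fluoro on the benzamide of compound 1

This account rests on a few compounds, and the source may have more. Where it says the series, first, only, none or still open, it means among the compounds named here.

For the measured compounds named here, compound 1, `NC(=O)c1c(NC(=O)c2ccccc2Cl)sc2c1CCN(C(=S)Nc1cc(C(F)(F)F)cc(C(F)(F)F)c1)C2`, is the only compound of this pair that gives a number in a functional assay on HL-60 cells (Homo sapiens) for antiproliferative activity, with a stated time of 24 h; a higher number here means a weaker inhibitor, a lower number a stronger inhibitor; compound 1 gives 6500 nM. Compound 2, `CCCCCC(=O)Nc1sc2c(c1C(N)=O)CCN(C(=S)NCCCC)C2`, gives > 50000 nM in this assay, which is a limit and not a number, so it marks (the limit of > 50000 nM in this assay, at which 1 of the 2 values shown sits). Compound 3, `NC(=O)c1c(NC(=O)c2ccccc2F)sc2c1CCN(C(=S)Nc1cc(C(F)(F)F)cc(C(F)(F)F)c1)C2`, has not been measured. It differs from compound 1 in one place: fluoro in place of chloro on an aromatic carbon of the ring of carbon only, ortho to a large group. Going by the values given here, no measured pair shows such a step here, so the expectation rests on the size of the change alone: one halogen for another, with no change in donors, acceptors or charge. The step from compound 1 to compound 3 is expected to be small, within or barely beyond the usual scatter, as a 1.4-fold higher number from compound 1 to compound 3 (0.14 log units; within the scatter). Compound 3 is therefore estimated at 9000 nM, between 3000 nM and 30000 nM.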

Compound 3, half-maximal inhibitory concentration: 17900 nM
Compound 3: middle estimate off by 2.0-fold (0.30 log units), on the low side; measured number inside the range.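

In this assay, for the compounds shown here, the change from 2-chlorophenyl to 2-fluorophenyl gives a 2.8-fold higher number from compound 1 to compound 3 (0.44 log units; beyond the scatter) and is the first measured step at this place. It shows that this position responds to the exchange of one halogen for another, even though the heavy-atom count, donors, acceptors and charge stay the same, and that chloro gives the stronger inhibitor of the two. Nothing shown here accounts for the size of this step.

From the compounds shown here alone, it remains open whether bromo or methyl at this place would match or improve on chloro, and how a phenyl ring with no halogen at all would compare. Also open, going by these compounds, is whether the same step would hold on a compound carrying something other than the 3,5-bis(trifluoromethyl)phenyl group of the thiourea.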